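This account rests on a few compounds, and the source may have more. Where it says the series, first, only, none or still open, it means among the compounds named here.

Measured compounds:
compound 1 `COc1cc2c(Oc3ccc(NC(=O)c4nn(-c5ccccc5)c(=O)c5ccccc45)cc3F)ccnc2cc1OCCCN1CCN(C)CC1` — 450 nM in a functional assay on NCI-H460 cells (Homo sapiens) for cytotoxicity, read by MTT assay, with a stated time of 72 h; on this read-out higher numbers stand for weaker inhibition and lower numbers for stronger inhibition
compound 2 `COc1cc2c(Oc3ccc(NC(=O)c4nn(-c5ccc(F)cc5)c(=O)c5ccccc45)cc3F)ccnc2cc1OCCCN1CCN(C)CC1` — compound 2 gives 91 nM
compound 3 `COc1cc2c(Oc3ccc(NC(=O)c4nn(-c5ccccc5)c(=O)c5ccccc45)cc3F)ccnc2cc1OCCCN1CCCCC1` — compound 3 gives 650 nM

The series shares one core; compound 1 and compound 3 differ only in the tail on the propoxy chain, (piperidin-1-yl in place of 4-methylpiperazin-1-yl on a saturated chain carbon, three bonds along the chain from an oxygen on an aromatic ring), and that swap moves the number little, a 1.4-fold higher number from compound 1 to compound 3 (0.16 log units; within the scatter). Compound 2 differs from compound 1 by fluoro in place of hydrogen on an aromatic carbon, and the number falls, a 4.9-fold lower number from compound 1 to compound 2 (0.69 log units; beyond the scatter). Compound 3 stands at the high end of the three numbers, though its gap to compound 1 is within the scatter.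

Compound 4 `COc1cc2c(Oc3ccc(NC(=O)c4nn(-c5ccccc5F)c(=O)c5ccccc45)cc3F)ccnc2cc1OCCCN1CCCCC1` is not yet measured. It differs from compound 3 by fluoro in place of hydrogen on an aromatic carbon. This is the same kind of change as that from compound 1 to compound 2, but not the same: there the fluorine sits para to a large group, here it sits ortho to a large group. Going by the values given here, no measured pair tells how a fluorine ortho to a large group behaves on this core, so the expectation rests on compound 3 at 650 nM and on the one measured fluorine step, a 4.9-fold lower number from compound 1 to compound 2 (0.69 log units; beyond the scatter), taken with less confidence.

For compound 4 the expected step is a 1.9-fold lower number from compound 3 to compound 4 (0.27 log units; within the scatter) in this assay. The estimate for compound 4 is 350 nM, with an expected range from 120 nM to 1000 nM.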

Compound 4, half-maximal inhibitory concentration: 160 nM
Compound 4: middle estimate off by 2.2-fold (0.34 log units), on the high side; measured number inside the range.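

In this assay, the change from phenyl to 2-fluorophenyl gives a 4.1-fold lower number from compound 3 to compound 4 (0.61 log units; beyond the scatter), and the size of this step can be set beside the earlier fluoro step on the other tail: the same change on two cores in this assay, a 4.9-fold lower number (0.69 log units; beyond the scatter) from compound 1 to compound 2 and a 4.1-fold lower number (0.61 log units; beyond the scatter) from compound 3 to compound 4, 1.2-fold (0.09 log units) apart, within the scatter of two such steps

On these two pairs, then, adding a fluoro to the phenyl ring lowers the number by a similar amount on both the 4-methylpiperazin-1-yl and the piperidin-1-yl versions of the shared core, so the step carries across this one tail change. It does not show that the place of the fluorine is irrelevant, since the fluorine in compound 4 stands ortho to a large group while that in compound 2 stands elsewhere on the ring, so the two steps differ in both tail and fluorine place, and two pairs in one cell assay set no general rule for the series.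

Still open, from the compounds shown here alone, is whether a chlorine, a methyl or a nitrile at the same place on the phenyl ring gives a step of similar size, and whether a second fluorine on that ring lowers the number further. Also open, going by these compounds, is how the fluoro step behaves with a morpholine tail or with a longer chain in place of the propoxy chain.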